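Cytotoxicity notes on an arylidene thiazolidinone series

The source may hold more compounds than are shown below. What is called first, only, known or untested is meant among the compounds shown, and "the series" means these compounds.

Measured so far:
compound 1 `O=C1/C(=C\c2ccc(O)cc2)S/C(=N/c2ccccc2)N1Cc1ccncc1`: 142000 nM
compound 2 `COc1ccc(/C=C2/S/C(=N/c3ccccc3)N(Cc3ccncc3)C2=O)cc1`: 47900 nM
compound 3 `COc1ccc(/C=C2/S/C(=N/c3ccccc3)N(Cc3ccncc3)C2=O)cc1OC`: 171000 nM

In an ADME assay on HEK293 cells (Homo sapiens) for cytotoxicity, read by MTT assay, with a stated time of 48 h (on this read-out higher numbers stand for weaker inhibition and lower numbers for stronger inhibition), compound 2 gives 47900 nM, the lowest of the three numbers. Compound 3 differs from compound 2 by methoxy in place of hydrogen on an aromatic carbon, and the step is a 3.6-fold higher number from compound 2 to compound 3 (0.55 log units; beyond the scatter). Compound 1 differs from compound 2 by hydrogen in place of methyl on an oxygen on an aromatic ring, with the step of a 3.0-fold higher number from compound 2 to compound 1 (0.47 log units; beyond the scatter). Compound 1 and compound 3 lie within the scatter of each other, as a 1.2-fold higher number from compound 1 to compound 3 (0.08 log units; within the scatter) shows.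

Compound 4 `COc1cc(/C=C2/S/C(=N/c3ccccc3)N(Cc3ccncc3)C2=O)ccc1O` is not yet measured in this assay. It differs from compound 3 by hydrogen in place of methyl on an oxygen on an aromatic ring. The place of this change is described in the same words as for the change from compound 2 to compound 1, so it is the same change, now made on the core of compound 3 rather than compound 2. Resting on a 3.0-fold higher number from compound 2 to compound 1 (0.47 log units; beyond the scatter), a step of similar direction is expected, though only one precedent exists and compound 3 already gives a high number. Compound 4 is expected to give 320000 nM, between 130000 nM and 800000 nM. The expected step is a 1.9-fold higher number from compound 3 to compound 4 (0.27 log units; within the scatter).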

Compound 4, half-maximal inhibitory concentration: 67400 nM
The estimate for compound 4 lay 4.7-fold (0.68 log units) above the measured number; measured number below the stated range.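

In this assay, hydrogen in place of methyl on an oxygen on an aromatic ring does not carry from one core to the other as a fixed step, and the direction reverses (a 2.5-fold lower number from compound 3 to compound 4 (0.40 log units; beyond the scatter)): the same change on two cores in this assay, a 3.0-fold higher number (0.47 log units; beyond the scatter) from compound 2 to compound 1 and a 2.5-fold lower number (0.40 log units; beyond the scatter) from compound 3 to compound 4, 7.5-fold (0.88 log units) apart, beyond the scatter of two such steps. Methoxy in place of hydrogen on an aromatic carbon reverses in the same way (a 2.1-fold lower number from compound 1 to compound 4 (0.32 log units; beyond the scatter)): the same change on two cores in this assay, a 3.6-fold higher number (0.55 log units; beyond the scatter) from compound 2 to compound 3 and a 2.1-fold lower number (0.32 log units; beyond the scatter) from compound 1 to compound 4, 7.5-fold (0.88 log units) apart, beyond the scatter of two such steps. The two changes therefore do not add up across these four compounds, with the remaining step (a 1.4-fold higher number from compound 2 to compound 4 (0.15 log units; within the scatter)) inside the scatter, but this does not show why, nor how the changes behave beyond this set.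

Still open, from the compounds shown here alone, is whether the reversal persists with an ethoxy group or an amine in place of the methoxy. Also open, going by these compounds, is whether it appears on any other core.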